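The source may hold more compounds than are shown below. What is called first, only, known or untested is meant among the compounds shown, and "the series" means these compounds.

Compound 1 `O=C(O)c1ccc(CN2C(=O)S/C(=C\c3cccnc3)C2=O)cc1` shows the highest of the three numbers measured in a functional assay on HeLa cells (Homo sapiens) for cytotoxicity, read by MTT assay, with a stated time of 24 h (on this read-out lower numbers stand for stronger inhibition and higher numbers for weaker inhibition), giving 88000 nM. Compound 2 `O=C(O)c1ccc(CN2C(=O)S/C(=C\c3ccncc3)C2=O)cc1` gives 60000 nM and compound 3 `O=C(O)c1ccc(CN2C(=O)S/C(=C\c3cccs3)C2=O)cc1` gives 76000 nM, so all three lie close together. The step of a 1.5-fold lower number from compound 1 to compound 2 (0.17 log units; within the scatter) and the step of a 1.2-fold lower number from compound 1 to compound 3 (0.06 log units; within the scatter) both stay inside the usual spread of repeated measurements. Compound 4 `O=C(O)c1ccc(CN2C(=O)S/C(=C\c3ccco3)C2=O)cc1` differs from compound 1 in one place: furan-2-yl in place of pyridin-3-yl on a double-bonded chain carbon bound to a double-bonded ring carbon. The step to compound 3, which also swaps pyridin-3-yl for a five-membered ring with one hetero atom, bears most on this change and was small. Compound 4 is therefore expected to give 75000 nM, within 35000 nM to 160000 nM, a step of a 1.2-fold lower number from compound 1 to compound 4 (0.07 log units; within the scatter) not beyond the scatter.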

Compound 4, half-maximal inhibitory concentration: 80000 nM
For compound 4 the middle estimate is 1.1-fold (0.03 log units) below the measured one; measured number inside the range.
By their numbers in this assay, from the lowest: compounds 2, 3, 4 and 1 (each within the scatter of the next).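

With furan-2-yl in place, the number in this assay still does not separate from the other three rings (a 1.1-fold lower number from compound 1 to compound 4 (0.04 log units; within the scatter)) (a 1.1-fold higher number from compound 3 to compound 4 (0.02 log units; within the scatter)) (a 1.3-fold higher number from compound 2 to compound 4 (0.12 log units; within the scatter)). So at this position, on a double-bonded chain carbon bound to a double-bonded ring carbon, neither going from a six-membered to a five-membered aromatic ring nor changing the hetero atom gives a step beyond the scatter. No measurement at hand offers an explanation for this. As far as these compounds go, whether an aminophenyl group or a simple propyl chain here would move the number beyond the scatter stays open.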